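The source may report more compounds than this note shows. Statements on the series, on what has been measured and on what is new or still open speak of the compounds shown alone.

Measured compounds:
- Compound 3, `Cc1ccc(-c2cnc(C(=O)CCCCCCc3ccccc3)o2)nc1`: 2.8 nM
- Compound 1, `N#Cc1cccc(-c2cnc(C(=O)CCCCCCc3ccccc3)o2)c1`: 15 nM
- Compound 2, `Nc1ccc(-c2cnc(C(=O)CCCCCCc3ccccc3)o2)cc1`: 90 nM

All three share a core and differ only in the aromatic group attached to it. In an assay (Rattus norvegicus) for inhibition of Fatty-acid amide hydrolase 1 (Homo sapiens) (on this read-out lower numbers stand for stronger inhibition and higher numbers for weaker inhibition), compound 3 gives the lowest number of the three, with compound 1 nearest and compound 2 furthest away. The step of a 5.4-fold lower number from compound 1 to compound 3 (0.73 log units; beyond the scatter) and the step of a 32-fold lower number from compound 2 to compound 3 (1.51 log units; beyond the scatter) both lie beyond the scatter, so compound 3 stands as the strongest of the measured set.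

Compound 4, `NS(=O)(=O)c1ccc(-c2cnc(C(=O)CCCCCCc3ccccc3)o2)s1`, differs from compound 3 in one place: 5-sulfamoylthiophen-2-yl in place of 5-methylpyridin-2-yl on an aromatic carbon.

Among the compounds with values here, no measured step exchanges a pyridine for a thiophene, so the closest guidance comes from the groups already compared. The step of a 32-fold lower number from compound 2 to compound 3 (1.51 log units; beyond the scatter) shows that the aryl group carrying a hydrogen-bond donor gave the weakest result, while the step of a 5.4-fold lower number from compound 1 to compound 3 (0.73 log units; beyond the scatter) shows that a second donor-free aryl group also fell short of compound 3. The entering group brings a hydrogen-bond donor and more acceptors than any measured aryl group, so a weaker result than compound 3 is expected, probably of modest size rather than as large as the step from compound 2.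

Compound 4 is therefore estimated at 25 nM, with a range of 6 nM to 100 nM, which means an expected step of an 8.9-fold higher number from compound 3 to compound 4 (0.95 log units; beyond the scatter).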

Compound 4, inhibition constant: 3 nM
Compound 4: middle estimate off by 8.3-fold (0.92 log units), on the high side; the whole stated range lies above it.
By their numbers in this assay, from the lowest: compounds 3 and 4 (each within the scatter of the next); then compound 1; then compound 2.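

In this assay, replacing 5-methylpyridin-2-yl with 5-sulfamoylthiophen-2-yl leaves the number within the scatter (a 1.1-fold higher number from compound 3 to compound 4 (0.03 log units; within the scatter)), so this position accepts two quite different aromatic groups, a six-membered ring and a larger five-membered one, with no readable change. The new group also shares the clear lead of compound 3 over the other two aromatic groups (a 30-fold lower number from compound 2 to compound 4 (1.48 log units; beyond the scatter); a 5.0-fold lower number from compound 1 to compound 4 (0.70 log units; beyond the scatter)), which shows that a hydrogen-bond donor on this group does not by itself go with a weak result: compound 4 carries one, as does compound 2, yet only compound 2 gives a high number. No measurement shown here explains why these groups perform as they do.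

The ring and its substituent change together in this step, so the compounds shown cannot separate their contributions; a thiophene ring carrying a methyl group, or a pyridine ring carrying a sulfamoyl group, would be needed to do that. On these data alone, it also remains open whether a carboxylic acid in place of the sulfamoyl group would give a similar number.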